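A few compounds are considered here, and "the series" means these few. Any claim that something is new, unique, unknown or untested is made for them only; others in the source may bear on it.

Compound 1 `CCCn1c(SCC(=O)Nc2ccc(C)cc2)nc2c1c(=O)[nH]c(=O)n2C` serves as the reference point here. In a functional assay on MGC-803 cells (Homo sapiens) for inhibition, read by MTT assay, with a stated time of 48 h, tested at 20 uM (a lower number here means less inhibition, a higher number more inhibition at the concentration tested (going by the name of the read-out)), compound 1 gives 42.2%. Compound 2 `Cn1cnc2c1c(=O)n(CC(=O)N1CCN(c3ccccc3)CC1)c(=O)n2C` is the other measured member of the set, and in this assay compound 2 gives 4.6%, the lowest of the two numbers; the number for compound 1 stands higher by a gap that is beyond the usual scatter. For the measured compounds named here, no pair of measured compounds differs in just one place, so no single-change step is available to guide what follows.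

Compound 3 `C=CC(=O)N1CCN(C(=O)Cn2c(=O)c3c(ncn3C)n(C)c2=O)CC1` has not yet been measured. It differs from compound 2 in one place: vinylcarbonyl in place of phenyl on an amine nitrogen in a ring. Going by the values given here, with no comparable step among the measured compounds, the expected step from compound 2 to compound 3 in this assay is small, perhaps a slight rise, and may not reach beyond the scatter: a number 5.4 percentage points higher from compound 2 to compound 3 (within the scatter). Compound 3 is therefore expected to give about 10%, in a range from 0% to 30%.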

Compound 3, a percentage reported as inhibition, at one concentration (the size of the read-out at that concentration, not a potency): 1.3%
Compound 3: middle estimate off by 8.7 percentage points, on the high side, and the stated range covers the measured number.
By their numbers in this assay, from the lowest: compounds 3 and 2 (each within the scatter of the next); then compound 1.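

In this assay the exchange of phenyl for vinylcarbonyl on the amine nitrogen in the ring comes out as a number 3.3 percentage points lower from compound 2 to compound 3 (within the scatter) so at this position an aromatic ring can give way to a smaller open group carrying a hydrogen-bond acceptor with no change that stands out from the usual scatter. Compound 2 gives 4.6% and compound 3 gives 1.3% at the one concentration tested, so neither group brings much inhibition and the pair has little room to show a further loss. Nothing measured here offers a reason for this result.

As far as these compounds go, whether any group at this nitrogen can raise the number stays open, for instance a benzyl group, a chlorophenyl ring or a longer chain. A reading at one concentration also leaves the potency of these compounds unknown.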